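Changing the aryl on the triazole of compound 3

This account rests on a few compounds, and the source may have more. Where it says the series, first, only, none or still open, it means among the compounds named here.

Compound 1 `CCOc1ccccc1-n1nncc1CN1C(=O)C2(C(C#N)=C(N)Oc3c2c2nc4ccccc4nc2c2ccccc32)c2ccccc21`: in a functional assay on MCF7 cells (Homo sapiens) for antiproliferative activity, read by MTT assay, with a stated time of 48 h (on this read-out higher numbers stand for weaker inhibition and lower numbers for stronger inhibition), compound 1 gives > 50000 nM, which is a limit of the assay rather than a number.
Compound 2 `N#CC1=C(N)Oc2c(c3nc4ccccc4nc3c3ccccc23)C12C(=O)N(Cc1cnnn1-c1ccc(S(N)(=O)=O)cc1)c1ccccc12`: in this assay compound 2 gives > 50000 nM, again a limit and not a number.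
Compound 3 `N#CC1=C(N)Oc2c(N)cc3nc4ccccc4nc3c2C12C(=O)N(Cc1cnnn1-c1ccccc1Br)c1ccccc12`: in this assay compound 3 gives 30700 nM.

Among the compounds with values here, compound 3 therefore stands as the only member of the set with an actual number; the two others sit at the limit (the limit of > 50000 nM in this assay, at which 2 of the 3 values shown sit), so no order between them and compound 3 can be read. Within the data shown here, the single measured change at the aromatic nitrogen, a step that the two limits leave unreadable from compound 1 to compound 2, is unreadable because both of its ends are limits (the limit of > 50000 nM in this assay, at which 2 of the 3 values shown sit); it tells neither size nor direction.

Compound 4 `Cc1ccc(Cl)cc1-n1nncc1CN1C(=O)C2(C(C#N)=C(N)Oc3c(N)cc4nc5ccccc5nc4c32)c2ccccc21` differs from compound 3 by 5-chloro-2-methylphenyl in place of 2-bromophenyl on an aromatic nitrogen. Among the measured compounds shown here, no measured step gives a readable size for a change at this position, so nothing in the set points to a shift beyond the usual scatter. Compound 4 is therefore expected to stay close to compound 3, with an estimated value of 30000 nM in a range from 10000 nM to 80000 nM, which means an expected step of a 1.0-fold lower number from compound 3 to compound 4 (0.01 log units; within the scatter) that amounts to essentially no change.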

Compound 4, half-maximal inhibitory concentration: 43500 nM
For compound 4 the middle estimate is 1.5-fold (0.16 log units) below the measured one, within the range that was stated.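

In this assay, within the data shown here, 5-chloro-2-methylphenyl in place of 2-bromophenyl on the aromatic nitrogen gives a 1.4-fold higher number from compound 3 to compound 4 (0.15 log units; within the scatter), the first step at this position whose size can be read. Compound 3 and compound 4 therefore cannot be told apart on this read-out, so in this pair the bromine can give way to a chlorine and a methyl group on the phenyl ring without a shift beyond the usual scatter. The only earlier step at this position cannot be read, as both of its ends are limits: the limit of > 50000 nM in this assay, at which 2 of the 4 values shown sit.

Going by these compounds, one readable step between two aryl groups says little about the position as a whole, so it remains open whether a phenyl ring carrying an amine or a carboxylic acid, or a longer chain in place of the phenyl ring, would move the number on the core of compound 3. Compound 1 and compound 2 differ from compound 3 in more than one place, so their 2-ethoxyphenyl and 4-sulfamoylphenyl groups cannot settle how such aryl groups would behave on that core.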